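The compounds below may be only part of what the source reports. "The series", "measured", "known", "first", "only" and "open" are said of these compounds alone.

Compound 1, `CCCCC#Cc1c(C)[nH]c2ccc(OC)cc2c1=O`: in a physicochemical assay for lipophilicity, at pH 7.4 (a higher number here means a more lipophilic compound, a lower number a more polar compound), compound 1 gives 5.25.
Compound 2, `CCCCC#Cc1c(C)[nH]c2ccc(Cl)cc2c1=O`: in this assay compound 2 gives 2.98.
Compound 3, `COc1ccc2c(=O)c(Cc3ccccc3)c(C)[nH]c2c1`: in this assay compound 3 gives 2.52.

Compound 1 and compound 2 share a core and differ in one place, (chloro in place of methoxy on an aromatic carbon). That single change made a step in this assay of a number 2.27 log units lower from compound 1 to compound 2 (beyond the scatter). Compound 3 carries a different core; how its core differs from that of compound 1 is not broken down here. In this assay compound 3 stands lowest of the three measured numbers.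

Compound 4, `Cc1[nH]c2cc(Cl)ccc2c(=O)c1Cc1ccccc1`, has not yet been measured. Among the measured compounds shown here, it arises from compound 3 by the same change, (chloro in place of methoxy on an aromatic carbon), on the same kind of place, so the step from compound 1 to compound 2 is the only guide. Because compound 1 to compound 2 gave a number 2.27 log units lower from compound 1 to compound 2 (beyond the scatter), a step in the same direction is expected from compound 3 to compound 4 in this assay, namely a number 1.52 log units lower from compound 3 to compound 4 (beyond the scatter), though with a single prior example its size is uncertain. Compound 4 is therefore expected to give about 1, between -0.5 and 2.8.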

Compound 4, distribution coefficient: 2.69
Estimate against measurement, compound 4: 1.69 log units below; the measured number falls inside the stated range.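

The swap of chloro in place of methoxy on an aromatic carbon does not behave alike on the two cores in this assay: on the core of compound 1 it gave a number 2.27 log units lower from compound 1 to compound 2 (beyond the scatter), while on the core of compound 3 it gave a number 0.17 log units higher from compound 3 to compound 4 (within the scatter). This shows that the large step seen on one core did not carry over to the other, so in this series the size of a step measured on one core is a poor guide to the step on a different core, though two pairs cannot show how often that happens or which difference between the cores matters. Nothing measured here accounts for the contrast between the two pairs.

The compounds shown leave open how this same swap behaves on any further core. They also leave open what this assay would read if an amine or a carboxylic acid stood on that aromatic carbon in place of methoxy.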